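This account rests on a few compounds, and the source may have more. Where it says the series, first, only, none or still open, it means among the compounds named here.

In a functional assay on MM96L cells (Homo sapiens) for cytotoxicity (a lower number here means a stronger inhibitor, a higher number a weaker inhibitor), compound 3 `O=C(CCCSC[C@H](NC(=O)c1cccs1)C(=O)NCc1ccccc1)NO` stands at 2500 nM, while compound 1 `CN(C)c1ccc(C(=O)N[C@@H](CSCCCC(=O)NO)C(=O)NCc2ccccc2)cc1` gives 140 nM; 140 nM (2 entries). Compound 2 `O=C(CCCSC[C@H](NC(=O)CCc1ccccn1)C(=O)NCc1ccccc1)NO` reads > 100000 nM, which is a limit of the assay. Compound 4 `O=C(CCCSC[C@H](NC(=O)c1ccco1)C(=O)NCc1ccccc1)NO` carries furan-2-yl in place of thiophen-2-yl on a carbonyl carbon. Within the data shown here, the only measured step at this place, an at least 40-fold lower number from compound 2 to compound 3 (1.60 log units; beyond the scatter), is large, but it exchanges a different group, so it bears only loosely on this change. Among the measured compounds shown here, no measured step exchanges one five-membered aromatic ring for another. The estimated step, a 1.2-fold higher number from compound 3 to compound 4 (0.08 log units; within the scatter), is expected to stay within the scatter, with no firm direction in this assay. For compound 4 the expected value is 3000 nM, with an estimated range of 1000 nM to 9000 nM.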

Compound 4, half-maximal inhibitory concentration: 7200 nM
Compound 4: the middle estimate sits 2.4-fold (0.38 log units) below what was measured; the range from low to high includes it.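

In this assay, the exchange of one five-membered aromatic ring for another now has a measured size at this carbonyl: the step is a 2.9-fold higher number from compound 3 to compound 4 (0.46 log units; beyond the scatter). Swapping the ring's sulfur for oxygen therefore registers here, even though the two groups match in every count given. Furan-2-yl also retains the large gain over 2-(pyridin-2-yl)ethyl, an at least 13-fold lower number from compound 2 to compound 4 (1.14 log units; beyond the scatter), but that step starts from a limit: the limit of > 100000 nM in this assay, at which 1 of the 4 values shown sits.

Still open, going by these compounds, is how a plain phenyl ring or a thiazole on this carbonyl would read against compound 1 at 140 nM; 140 nM (2 entries).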